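A Pyrimidine Replaces the Aryl Group on the Sulfonyl Sulfur

The compounds below may be only part of what the source reports. "The series", "measured", "known", "first", "only" and "open" are said of these compounds alone.

Compound 3 `Cc1cccc(S(=O)(=O)c2ccc(NC(=O)C(C)(O)C(F)(F)F)cc2)c1` shows the lowest number of the three measured in a functional assay (Cavia porcellus) with sulfonylurea receptors; K-ATP channels (Homo sapiens) as the target (on this read-out higher numbers stand for weaker inhibition and lower numbers for stronger inhibition), giving 2200 nM. Compound 2 `Cc1ccccc1S(=O)(=O)c1ccc(NC(=O)C(C)(O)C(F)(F)F)cc1` gives 5100 nM and compound 1 `CC(O)(C(=O)Nc1ccc(S(=O)(=O)c2cccc(Cl)c2)cc1)C(F)(F)F` gives 10000 nM; the steps among them were a 2.0-fold lower number from compound 1 to compound 2 (0.29 log units; within the scatter), a 2.3-fold lower number from compound 2 to compound 3 (0.37 log units; beyond the scatter) and a 4.5-fold lower number from compound 1 to compound 3 (0.66 log units; beyond the scatter). Compound 4 `CC(O)(C(=O)Nc1ccc(S(=O)(=O)c2cncnc2)cc1)C(F)(F)F` carries the change (pyrimidin-5-yl in place of 3-methylphenyl on a sulfonyl sulfur). The measured steps all alter the ring on the sulfonyl sulfur, but none exchanges it for a ring bearing hetero atoms, so they bear on this step only loosely; all three moves were modest or within the scatter. A step of a 2.3-fold higher number from compound 3 to compound 4 (0.36 log units; beyond the scatter) is therefore expected, with the number estimated to rise. Compound 4 is expected to give 5000 nM, in the range 1500 nM to 30000 nM.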

Compound 4, half-maximal inhibitory concentration: > 30000 nM
Compound 4 ended at the assay's limit; the forecaster's own chance of this, stated with the estimate: 20%; at least 6.0-fold (0.77 log units) between middle value and limit.
By their numbers in this assay, from the lowest: compound 3; then compounds 2 and 1 (each within the scatter of the next). At a limit, above all of these: compound 4.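

The value of compound 4 is a limit of the assay and not a number: the limit of > 30000 nM in this assay, at which 1 of the 4 values shown sits. Going by these compounds alone, the ring on the sulfonyl sulfur proves far more sensitive to this exchange than the earlier compounds suggested: an at least 13-fold higher number from compound 3 to compound 4 (1.13 log units; beyond the scatter) exceeds every step among those compounds, while an at least 5.8-fold higher number from compound 2 to compound 4 (0.76 log units; beyond the scatter) and an at least 3.0-fold higher number from compound 1 to compound 4 (0.47 log units; beyond the scatter) point the same way. All three carbon-only rings give measurable numbers, and only the ring with hetero atoms reaches the limit.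

The compounds shown leave open how much of the step belongs to the ring nitrogens and how much to losing the methyl or chloro group. An unsubstituted phenyl or a pyridyl group on the sulfonyl sulfur would separate the two.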